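The source may report more compounds than this note shows. Statements on the series, on what has been measured and on what is new or still open speak of the compounds shown alone.

Measured in a functional assay on HeLa cells (Homo sapiens) for inhibition, read by cell counting, with a stated time of 4 days; on this read-out higher numbers stand for weaker inhibition and lower numbers for stronger inhibition:

- compound 1 `C=C(Br)C(=O)Nc1cccc(-c2cn3nc(-c4ccc(F)cc4)sc3n2)c1`: 870 nM
- compound 2 `C=C(Br)C(=O)Nc1cccc(-c2cn3nc(-c4ccc(Cl)cc4)sc3n2)c1`: 3000 nM
- compound 3 `Nc1cccc(-c2cn3nc(-c4ccc(Cl)cc4)sc3n2)c1`: 160000 nM

Compound 2 and compound 1 differ in one place, (fluoro in place of chloro on an aromatic carbon). In this assay this gives a 3.4-fold lower number from compound 2 to compound 1 (0.54 log units; beyond the scatter), a modest step.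

Compound 3 differs from compound 2 by hydrogen in place of (1-bromoethenyl)carbonyl on a nitrogen on an aromatic ring. That change gives a 53-fold higher number from compound 2 to compound 3 (1.73 log units; beyond the scatter), by far the largest step in the set, and compound 3 stands as the highest number of the three measured compounds, with both of its steps to the others beyond the scatter.

Compound 4 `Nc1cccc(-c2cn3nc(-c4ccc(F)cc4)sc3n2)c1` is not yet measured. It differs from compound 3 by fluoro in place of chloro on an aromatic carbon. This is the same change as that from compound 2 to compound 1: the two descriptions of the place agree word for word, the group that leaves and the group that enters are the same. The two cores on which the change is made differ as described by hydrogen in place of (1-bromoethenyl)carbonyl on a nitrogen on an aromatic ring.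

For the measured compounds named here, on the one measured pair the change is modest in size, and there is no second pair to show whether it carries over to the core of compound 3. The expected step for compound 4 is a 2.9-fold lower number from compound 3 to compound 4 (0.46 log units; beyond the scatter), resting on the measured pair that gave a 3.4-fold lower number from compound 2 to compound 1 (0.54 log units; beyond the scatter). Compound 4 is therefore estimated at 55000 nM, with a range from 20000 nM to 200000 nM. Compound 3 already gives 160000 nM, the highest number of the three measured compounds, and compound 4 is expected to stay in that upper region.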

Compound 4, half-maximal inhibitory concentration: >= 250000 nM
Compound 4 was reported as a limit (the forecaster's own chance of this, stated with the estimate: 25%); middle value at least 4.5-fold (0.65 log units) from the limit.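

In this assay compound 4 gives >= 250000 nM, which is a limit of the assay and not a number. On the core of compound 3, fluoro in place of chloro gives an at least 1.5-fold higher number from compound 3 to compound 4 (0.19 log units; that floor lies within the scatter), so the result on this core does not match the step seen on the core of compound 2, and the change does not carry over unaltered between these two cores: the same change on two cores in this assay, a 3.4-fold lower number (0.54 log units; beyond the scatter) from compound 2 to compound 1 and an at least 1.5-fold higher number (0.19 log units; that floor lies within the scatter) from compound 3 to compound 4, at least 5.3-fold (0.73 log units) apart, beyond the scatter of two such steps Hydrogen in place of (1-bromoethenyl)carbonyl on the fluoro side gives an at least 280-fold higher number from compound 1 to compound 4 (2.45 log units; beyond the scatter), but with one pair per core and a limit at one end the gap between the two cores is known only as a floor, and nothing here shows how the change would behave on any further core: the same change on two cores in this assay, a 53-fold higher number (1.73 log units; beyond the scatter) from compound 2 to compound 3 and an at least 280-fold higher number (2.45 log units; beyond the scatter) from compound 1 to compound 4, at least 5.3-fold (0.73 log units) apart, beyond the scatter of two such steps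

On the nitrogen, the compounds shown carry only hydrogen or (1-bromoethenyl)carbonyl, so it remains open whether an acetyl or a plain acryloyl group, without the bromine, would give the same dependence of the halogen step on the core. At the place on the 4-chlorophenyl and 4-fluorophenyl ring, only the two halogens appear, which leaves open how hydrogen, methyl or methoxy would read on either core.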